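Trifluoromethyl in Place of Fluoro: An Expected Antiproliferative Value

The source may hold more compounds than are shown below. What is called first, only, known or untested is meant among the compounds shown, and "the series" means these compounds.

Compound 1, `COc1ccc2nc(C)cc(NCc3ccccc3F)c2c1`: 17000 nM
Compound 2, `COc1ccc2nc(C)cc(NCc3c(F)cccc3F)c2c1`: 13600 nM

Of the compounds shown here, two have been measured in a functional assay on MCF-10A cells (Homo sapiens) for antiproliferative activity, with a stated time of 48 h; a lower number here means that less compound is needed, a higher number that more compound is needed for the effect. Compound 1 gives 17000 nM, and compound 2 gives 13600 nM. Going by the values given here, the single measured step, a 1.3-fold lower number from compound 1 to compound 2 (0.10 log units; within the scatter), leaves the two values within the scatter of each other, so compound 2 stands level with compound 1 on these numbers rather than apart from it.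

Compound 3 `COc1ccc2nc(C)cc(NCc3c(F)cccc3C(F)(F)F)c2c1` differs from compound 2 by trifluoromethyl in place of fluoro on an aromatic carbon. Among the compounds with values here, no measured step involves a trifluoromethyl group, and the one step that has been measured, fluoro in place of hydrogen, stayed within the scatter. The data therefore give no ground to expect a shift beyond the scatter in this assay in either direction.

Compound 3 is accordingly expected to give 11000 nM, with a range from 4000 nM to 30000 nM, which corresponds to an expected step of a 1.2-fold lower number from compound 2 to compound 3 (0.09 log units; within the scatter).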

Compound 3, half-maximal effective concentration: 14000 nM
The estimate for compound 3 lay 1.3-fold (0.10 log units) below the measured number; the measured number falls inside the stated range.
By their numbers in this assay, from the lowest: compounds 2, 3 and 1 (each within the scatter of the next).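

With the trifluoromethyl group in place of fluoro, this assay gives a 1.0-fold higher number from compound 2 to compound 3 (0.01 log units; within the scatter), so a group of several more heavy atoms at this position leaves the number within the scatter. Set against hydrogen at the same place, the trifluoromethyl group gives a 1.2-fold lower number from compound 1 to compound 3 (0.08 log units; within the scatter), so this position has now carried hydrogen, fluoro and trifluoromethyl without any step leaving the scatter, where the earlier compounds had shown only the exchange of hydrogen for fluoro. No available data explain why these exchanges leave the number within the scatter.

From the compounds shown here alone, it remains open whether a group of another kind at this position, such as an amine or a carboxylic acid, would take the number beyond the scatter. Also open, going by these compounds, is whether the same holds for a longer chain there, or with the other fluoro group on this ring exchanged.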